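Swapping imidazolyl for furanyl on a shared core

The source may report more compounds than this note shows. Statements on the series, on what has been measured and on what is new or still open speak of the compounds shown alone.

Measured compounds:
- compound 1 `Cn1nc2c(=O)n(CC3(O)CCN(Cc4ccc(-n5ccnc5)cc4Cl)CC3)cnc2c1-c1ccc(CN)cc1`: 228 nM
- compound 2 `CN(C)Cc1ccc(-c2c3ncn(CC4(O)CCN(Cc5ccc(-c6ccco6)cc5Cl)CC4)c(=O)c3nn2C)cc1`: 131 nM
- compound 3 `Cn1nc2c(=O)n(CC3(O)CCN(Cc4ccc(-c5ccco5)cc4Cl)CC3)cnc2c1-c1ccc(C(=N)N)cc1`: 87.5 nM

All three share one core and differ only in the groups hung on its two outer aromatic rings. In an assay on isolated protein for inhibition of ubiquitin carboxyl-terminal hydrolase 7 (Homo sapiens), with stated times of 30 min and 2 h (a lower number here means a stronger inhibitor, a higher number a weaker inhibitor), compound 1 gives 228 nM, the highest of the three numbers. Its gap to compound 2 lies within the scatter, while its gap to compound 3 lies beyond it. Among the compounds with values here, the one directly comparable step, a 1.5-fold lower number from compound 2 to compound 3 (0.18 log units; within the scatter), touches the other end of the molecule and stays within the scatter.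

Compound 4 `Cn1nc2c(=O)n(CC3(O)CCN(Cc4ccc(-c5ccoc5)cc4Cl)CC3)cnc2c1-c1ccc(CN)cc1` is the next compound. It differs from compound 1 in one place: furan-3-yl in place of 1H-imidazol-1-yl on an aromatic carbon. Within the data shown here, no measured pair isolates this change; compound 2 and compound 3 carry a different furanyl group together with other differences, so they only hint that such ring swaps have not moved the numbers far. The expectation is therefore a step of modest size at most, with direction uncertain, so that a 1.4-fold lower number from compound 1 to compound 4 (0.15 log units; within the scatter) is expected. Compound 4 is estimated at 160 nM, with a range from 60 nM to 420 nM.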

Compound 4, half-maximal inhibitory concentration: 177 nM
Estimate against measurement, compound 4: 1.1-fold (0.04 log units) below; the measured number falls inside the stated range.
By their numbers in this assay, from the lowest: compounds 3, 2, 4 and 1 (each within the scatter of the next, the first and the last beyond it).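

Within the data shown here, this is the first pair that isolates the ring at this position, on the aromatic carbon para to a large group and meta to the chloro group. In this assay, replacing 1H-imidazol-1-yl with furan-3-yl gives a 1.3-fold lower number from compound 1 to compound 4 (0.11 log units; within the scatter), so the two compounds cannot be told apart. At this position, then, a five-membered aromatic ring with one hetero atom and one hydrogen-bond acceptor can stand in for one with two of each without a measurable step, though the data shown offer no explanation for this.

From the compounds shown here alone, it remains open whether a morpholine, a carboxylic acid or a plain phenyl ring at this position would give a step beyond the scatter. Also open, going by these compounds, is whether this swap gives an equally small step when the other outer ring carries a different group.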